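A few compounds are considered here, and "the series" means these few. Any claim that something is new, unique, unknown or untested is made for them only; others in the source may bear on it.

Measured so far:
compound 1, `CCC1(Cc2ccccc2)OS(=O)(=O)C=C1OCC#N`: > 200000 nM
compound 2, `CCC1(Cc2ccccc2)OS(=O)(=O)C=C1OCC=C(C)C`: 112000 nM

In an ADME assay on HEL cells (Homo sapiens) for cytotoxicity, with a stated time of 3 days (a higher number here means that more compound is tolerated, a lower number that less compound is tolerated), compound 1 gives only a limit of the assay, > 200000 nM. In this assay compound 2 gives 112000 nM. Going by the values given here, compound 2 thus holds the only number; the other value is a limit (the limit of > 200000 nM in this assay, at which 1 of the 2 values shown sits). Among the compounds with values here, the step of an at least 1.7-fold lower number from compound 1 to compound 2 (0.25 log units; that floor lies within the scatter) is the one measured step, and it does not leave the scatter.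

Compound 3, `CCC1(Cc2ccccc2)OS(=O)(=O)C=C1OCCc1ccccc1`, differs from compound 2 in one place: benzyl in place of 2-methylprop-1-en-1-yl on a saturated chain carbon bound to an oxygen on an unsaturated carbon. Within the data shown here, the only measured step at this place is an at least 1.7-fold lower number from compound 1 to compound 2 (0.25 log units; that floor lies within the scatter), and it is within the scatter, so no step beyond the scatter is expected in this assay for compound 3. The estimate for compound 3 is 90000 nM, with a range from 40000 nM to 200000 nM. This estimate means a step of a 1.2-fold lower number from compound 2 to compound 3 (0.09 log units; within the scatter), which is expected to stay within the scatter.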

Compound 3, half-maximal cytotoxic concentration: 48000 nM
Beside the measured number, compound 3's estimate is 1.9-fold (0.27 log units) above it; the measured number falls inside the stated range.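

In this assay, benzyl in place of 2-methylprop-1-en-1-yl gives a 2.3-fold lower number from compound 2 to compound 3 (0.37 log units; beyond the scatter) and shows that a change at this place, on a saturated chain carbon bound to an oxygen on an unsaturated carbon, can leave the scatter even between two measured numbers. At the same place, benzyl in place of cyano gives an at least 4.1-fold lower number from compound 1 to compound 3 (0.61 log units; beyond the scatter) and also leaves the scatter. That size is only a floor, because compound 1 gives only a limit of the assay: the limit of > 200000 nM in this assay, at which 1 of the 3 values shown sits.

With phenethyl as the only group here that carries an aromatic ring, the compounds shown do not separate the ring from the larger heavy-atom count. From the compounds shown here alone, whether the lower number holds for a saturated group such as 2-cyclohexylethyl, or extends to a longer chain such as 3-phenylpropyl, remains open.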